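The source may report more compounds than this note shows. Statements on the series, on what has been measured and on what is new or still open speak of the compounds shown alone.

The measured compounds are:
compound 1 `C[C@H](NC(=O)[C@@]1(Cc2ccccc2)CCN1C(=O)OCc1ccccc1)C(=O)NC(C)(C)C` with > 100000 nM
compound 2 `C[C@H](NC(=O)[C@]1(Cc2ccccc2)CCN1C(=O)Oc1cccc2ccccc12)C(N)=O` with > 100000 nM

In an ADME assay on HELF cells (Homo sapiens) for cytotoxicity, with a stated time of 3 days (on this read-out lower numbers stand for higher toxicity in this test and higher numbers for lower toxicity in this test), compound 1 gives > 100000 nM, which is a limit of the assay and not a number. Compound 2 gives > 100000 nM, likewise a limit. So compound 1 stands at the limit of > 100000 nM in this assay, at which 2 of the 2 values shown sit, and nothing separates the two measured compounds in this assay.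

Compound 3 `CC(C)C[C@H](NC(=O)[C@@]1(Cc2ccccc2)CCN1C(=O)OCc1ccccc1)C(N)=O` is the unmeasured compound of interest. It differs from compound 1 in one place: 1-carbamoyl-3-methylbutyl in place of 1-((tert-butyl)carbamoyl)ethyl on an amide-type nitrogen. For the measured compounds named here, no step between two measured compounds is available to guide the expectation, and both measured compounds sit at the same limit. The step from compound 1 to compound 3 is therefore expected to be a step that the limit leaves unreadable from compound 1 to compound 3, that is, nothing beyond the scatter. Compound 3 is accordingly estimated at 150000 nM, between 50000 nM and 500000 nM, most likely reported again only as a limit.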

Compound 3, minimum cytotoxic concentration: > 100000 nM
Compound 3: no number, only a limit (the forecaster's own chance of this, stated with the estimate: 80%); the middle value does not contradict the limit.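

In this assay, for the compounds shown here, compound 3 gives > 100000 nM and this is a limit, not a number, so no step from compound 1 to compound 3 can be read. The compounds shown leave open at what concentration, if any, each would turn toxic in this test: the limit of > 100000 nM in this assay, at which 3 of the 3 values shown sit.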